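Growth inhibition after a change to 4-ethylphenyl

The source may report more compounds than this note shows. Statements on the series, on what has been measured and on what is new or still open speak of the compounds shown alone.

Of the compounds shown here, two with a shared core have been tested in a functional assay on RXF 393 cells (Homo sapiens) for inhibition, read by sulforhodamine B assay, with a stated time of 48 h; a lower number here means a stronger inhibitor of growth, a higher number a weaker inhibitor of growth. In that test, compound 1 `Cc1ccc(C2=NN(c3ccc(S(C)(=O)=O)cc3)C(=O)CC2)cc1` gives 6800 nM. Compound 2 `Cc1cc(O)ccc1C1=NN(c2ccc(S(C)(=O)=O)cc2)C(=O)CC1` gives only > 100000 nM, and this is a limit of the assay, not a number.

The next compound, compound 3 `CCc1ccc(C2=NN(c3ccc(S(C)(=O)=O)cc3)C(=O)CC2)cc1`, has 4-ethylphenyl in place of 4-hydroxy-2-methylphenyl on a carbon with a double bond to nitrogen.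

Among the compounds with values here, one measured step bears on this change: an at least 14-fold higher number from compound 1 to compound 2 (1.16 log units; beyond the scatter). It is large, lies beyond the scatter, and came with 4-hydroxy-2-methylphenyl in place of 4-methylphenyl. Compound 3 gives up that same group, and its 4-ethylphenyl is close in name and make-up to the 4-methylphenyl of compound 1 at 6800 nM. As far as these compounds go, a large step towards a lower number is therefore expected, roughly undoing the measured one, although its exact size stays open while compound 2 has only a limit. The expected step is an at least 14-fold lower number from compound 2 to compound 3 (1.15 log units; beyond the scatter). In this assay the estimated value for compound 3 is 7000 nM, with an expected range of 2000 nM to 25000 nM.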

Compound 3, concentration for total growth inhibition: 19800 nM
Compound 3: the middle estimate sits 2.8-fold (0.45 log units) below what was measured; the measured number falls inside the stated range.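

Moving from 4-hydroxy-2-methylphenyl to 4-ethylphenyl on the carbon with a double bond to nitrogen brings growth inhibition back into a measurable range in this assay, with an at least 5.0-fold lower number from compound 2 to compound 3 (0.70 log units; beyond the scatter). This shows that the poor result for compound 2 does not extend to every change of the aromatic group at this position. The position also responds to a small change in the chain: putting methyl in place of hydrogen on the saturated chain carbon bound to an aromatic carbon, which turns 4-methylphenyl into 4-ethylphenyl, gives a 2.9-fold higher number from compound 1 to compound 3 (0.46 log units; beyond the scatter), so the ethyl group is the weaker of the two here.

The true size of the first step stays open, as the figure for compound 2 is a limit of the assay and not a number: the limit of > 100000 nM in this assay, at which 1 of the 3 values shown sits.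

As far as these compounds go, it also remains open whether a longer chain such as propyl would continue this trend, and whether the hydroxy group or the 2-methyl group accounts for the poor result of compound 2, which a simple 4-hydroxyphenyl group could help to separate.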